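Sulfonyl aryl exchange in the quinoline sulfone series

The compounds below may be only part of what the source reports. "The series", "measured", "known", "first", "only" and "open" are said of these compounds alone.

Measured so far:
- compound 1 `O=S(=O)(c1ccc(F)c(Cl)c1)c1cnc2c(F)cccc2c1-c1cccc(Cl)c1`: 0.18 mL/min
- compound 2 `O=S(=O)(c1ccc(F)c(Cl)c1)c1cnc2c(F)cccc2c1-c1ccc(F)cc1`: 0.19 mL/min
- compound 3 `O=S(=O)(c1ccc(F)c(Cl)c1)c1cnc2c(F)cccc2c1-c1cccc(F)c1`: 1.23 mL/min

In an ADME assay on microsomes from liver (Homo sapiens) for metabolic stability, tested at 2.5 uM (a higher number here means faster removal of the compound, a lower number slower removal), compound 2 stands second highest of the three numbers; compound 1 sits within the scatter of it, with a 1.1-fold higher number from compound 1 to compound 2 (0.02 log units; within the scatter), while compound 3 lies well above it, with a 6.5-fold higher number from compound 2 to compound 3 (0.81 log units; beyond the scatter). The other step that is beyond the scatter is a 6.8-fold higher number from compound 1 to compound 3 (0.83 log units; beyond the scatter).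

Compound 4 `O=S(=O)(c1cccc(F)c1)c1cnc2c(F)cccc2c1-c1ccc(F)cc1` differs from compound 2 at the sulfonyl sulfur: 3-fluorophenyl in place of 3-chloro-4-fluorophenyl on a sulfonyl sulfur.

Among the measured compounds shown here, none of the measured steps touches the group on the sulfonyl sulfur; all three concern the aryl on the core carbon. For the measured compounds named here, of those, the two that exchange fluoro for chloro or move a fluoro on that aryl gave modest rises in this assay, and the one that swaps a chlorophenyl for a fluorophenyl stayed within the scatter. On these data alone, the present change also removes a chlorine and keeps one fluorine, so a rise of similar or smaller size is expected, though with wide uncertainty since the position is untested. The expected step is a 1.8-fold higher number from compound 2 to compound 4 (0.27 log units; within the scatter). Compound 4 is estimated at 0.35 mL/min, with a range from 0.12 mL/min to 1.2 mL/min.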

Compound 4, intrinsic clearance in a liver preparation (reported as CLH), per the amount of preparation that the assay uses: 0.19 mL/min
The estimate for compound 4 lay 1.8-fold (0.27 log units) above the measured number; low and high end bracket the measured number.
By their numbers in this assay, from the lowest: compounds 1, 2 and 4 (each within the scatter of the next); then compound 3.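

Among the compounds shown here, this is the first step at the sulfonyl sulfur: in this assay, 3-fluorophenyl in place of 3-chloro-4-fluorophenyl gives no change at the digits printed from compound 2 to compound 4 (within the scatter). For this pair, with the 4-fluorophenyl on the core carbon held fixed, the chlorine-bearing aryl on the sulfonyl sulfur can therefore be exchanged for the simpler 3-fluorophenyl without a step beyond the scatter, whereas the earlier exchanges on the core aryl included steps beyond it. Nothing shown here bears on why this exchange leaves the read-out within the scatter.

On these data alone, this rests on a single pair, so it remains open whether the same exchange would stay within the scatter with the 3-fluorophenyl of compound 3 on the core carbon, where the number is already well separated from those of compound 1 and compound 2. Also open, as far as these compounds go, is how this position responds to groups of a different kind on the sulfonyl sulfur, such as a morpholine or a pyridine in place of the aryl, or an amine or a carboxylic acid carried on it.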